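A few compounds are considered here, and "the series" means these few. Any claim that something is new, unique, unknown or untested is made for them only; others in the source may bear on it.

Working notes on the series. Two compounds have numbers in a functional assay (cardiac atrium) for agonist activity, with Cavia porcellus as the target; on this read-out higher numbers stand for an effect only at larger amounts of compound and lower numbers for an effect already at smaller amounts. Compound 2, `CC1=NC(C)=C([N+](=O)[O-])C(c2ccncc2)/C1=C(\O)OC1CCCCC1`, gives 4940 nM in this assay. Compound 1, `CC1=NC(C)=C([N+](=O)[O-])C(c2ccccn2)/C1=C(\O)OCC(C)C`, gives 9100 nM in this assay; the gap between compound 2 and compound 1 lies within the usual scatter of this assay, so the two cannot be told apart, and compound 1 differs from compound 2 in more than one place.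

Compound 3, `CC1=NC(C)=C([N+](=O)[O-])C(c2ccncc2)/C1=C(\O)OCC(C)C`, has not yet been measured in this assay. It differs from compound 2 in one place: isobutyl in place of cyclohexyl on an oxygen on an unsaturated carbon. Going by the values given here, no measured pair shows this change on its own, so no step for it is known here.

On the numbers shown, compound 3 is expected to stay near compound 2, with a step from a 1.4-fold higher number from compound 2 to compound 3 (0.15 log units; within the scatter) that is small and may not exceed the scatter. For compound 3 in this assay the estimate is 7000 nM, with a range from 2500 nM to 20000 nM.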

Compound 3, half-maximal effective concentration: 8510 nM
Compound 3: middle estimate off by 1.2-fold (0.08 log units), on the low side; measured number inside the range.
By their numbers in this assay, from the lowest: compounds 2, 3 and 1 (each within the scatter of the next).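

In this assay, the exchange of cyclohexyl for isobutyl on the oxygen on an unsaturated carbon can now be read on its own: a 1.7-fold higher number from compound 2 to compound 3 (0.24 log units; within the scatter) shows that the two groups cannot be told apart at this place, even though the ring is lost and the group holds fewer carbons. Going by these compounds alone, the change on the saturated ring carbon can also be read alone for the first time, and a 1.1-fold lower number from compound 1 to compound 3 (0.03 log units; within the scatter) leaves pyridin-4-yl and pyridin-2-yl equally indistinguishable there.

From the compounds shown here alone, it remains open whether a longer chain, or a chain carrying an amine or a carboxylic acid, on this oxygen would give a step beyond the scatter. The same question stands for pyridin-3-yl or phenyl on the saturated ring carbon. No measurement shown here offers an explanation for these results.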